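This account rests on a few compounds, and the source may have more. Where it says the series, first, only, none or still open, it means among the compounds named here.

Compound 1, `CCOC(=O)c1cccc(-c2ccc(OCC)cc2)c1`, gives 50000 nM in an assay on COS-7 cells for inhibition of patatin-like phospholipase domain-containing protein 2 (Mus musculus); a higher number here means a weaker inhibitor, a lower number a stronger inhibitor. Compound 2, `CCOC(=O)c1cccc(-c2ccc(N(C)C)cc2)c1`, gives 40000 nM in this assay.

Compound 2 thus holds the lower of the two numbers, but its gap to compound 1 lies within the scatter, so the pair stands together. Compound 3, `CCOC(=O)c1cccc(-c2ccc([N+](=O)[O-])cc2)c1`, differs from compound 2 by nitro in place of dimethylamino on an aromatic carbon. Among the compounds with values here, the one measured step at this position, a 1.3-fold lower number from compound 1 to compound 2 (0.10 log units; within the scatter), stayed within the scatter, so a further swap of the group there is expected to shift this assay little, if at all. Compound 3 is therefore expected to give 50000 nM, with a range of 20000 nM to 150000 nM, which would mean a 1.3-fold higher number from compound 2 to compound 3 (0.10 log units; within the scatter).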

Compound 3, half-maximal inhibitory concentration: 95000 nM
Estimate against measurement, compound 3: 1.9-fold (0.28 log units) below; the measured number falls inside the stated range.
By their numbers in this assay, from the lowest: compounds 2, 1 and 3 (each within the scatter of the next, the first and the last beyond it).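

In this assay, within the data shown here, the change at this position gives a 2.4-fold higher number from compound 2 to compound 3 (0.38 log units; beyond the scatter) and so the first step here that lies beyond the scatter, though only modestly. The other step, a 1.9-fold higher number from compound 1 to compound 3 (0.28 log units; within the scatter) with nitro in place of ethoxy, stays within the scatter, so only dimethylamino and nitro are told apart at this position. No measurement at hand accounts for this difference.

From the compounds shown here alone, whether a primary amine, a carboxylic acid or a longer alkoxy chain on this aromatic carbon would move the number stays open. So does whether any group here can bring a much stronger inhibitor.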